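A few compounds are considered here, and "the series" means these few. Any claim that something is new, unique, unknown or untested is made for them only; others in the source may bear on it.

Compound 1 `O=C(Nc1cccc(-n2cc(-c3ccncc3)c(-c3cc(O)cc(Cl)c3)n2)c1)Nc1ccc(Cl)c(C(F)(F)F)c1` stands at -30% in a functional assay on RPMI-8226 cells (Homo sapiens) for inhibition, read by sulforhodamine B assay, with a stated time of 48 h, tested at 100 uM (a higher number here means a weaker effect of the compound at the concentration tested, a lower number a stronger effect), with compound 2 `O=C(Nc1cccc(-n2cc(-c3ccncc3)c(-c3cc(O)cc(Cl)c3)n2)c1)Nc1ccc(Cl)c(Cl)c1` alongside it at -27%; the step of a number 3 percentage points higher from compound 1 to compound 2 (within the scatter) is the only one measured. Compound 3 `COc1cc(Cl)cc(-c2nn(-c3cccc(NC(=O)Nc4ccc(Cl)c(C(F)(F)F)c4)c3)cc2-c2ccncc2)c1` differs from compound 1 by methyl in place of hydrogen on an oxygen on an aromatic ring. Among the compounds with values here, that single measured step, a number 3 percentage points higher from compound 1 to compound 2 (within the scatter), concerns chloro in place of trifluoromethyl on an aromatic carbon and does not bear on this change; no measured step does. Compound 3 is thus expected to sit near compound 1, with a step of a number 5 percentage points higher from compound 1 to compound 3 (within the scatter) expected to stay within the scatter. The estimate for compound 3 is -25%, between -60% and 20%.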

Compound 3, a percentage reported as activity, at one concentration (the size of the read-out at that concentration, not a potency): -32%
Compound 3: middle estimate off by 7 percentage points, on the high side, within the range that was stated.
By their numbers in this assay, from the lowest: compounds 3, 1 and 2 (each within the scatter of the next).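

Replacing the hydrogen on this oxygen with methyl, hydroxy to methoxy, gives a number 2 percentage points lower from compound 1 to compound 3 (within the scatter) in this assay. For this pair, then, the read-out at the tested concentration does not depend on a free hydroxy on the 3-chloro-5-hydroxyphenyl ring, and a methyl on that oxygen is tolerated. Nothing available explains why the two compounds read alike. Still open, going by these compounds, is whether a longer chain on this oxygen, or an amine or a carboxylic acid in place of the hydroxy, would read the same. On these data alone, it is also open whether methoxy behaves this way alongside chloro in place of trifluoromethyl.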